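The compounds below may be only part of what the source reports. "The series", "measured", "known", "first", "only" and "open" are said of these compounds alone.

Working notes on the series.

Within the data shown here, compound 1 `CC[C@H](CCn1cncn1)c1ccc(C)cc1` in an ADME assay on RD cells (Homo sapiens) for cytotoxicity, read by MTT assay, with a stated time of 3 days (on this read-out higher numbers stand for lower toxicity in this test and lower numbers for higher toxicity in this test), gives 85.2 ug/mL, the second highest of the three numbers so far; its nearest neighbour is compound 2 and its furthest is compound 3, and both gaps sit within the scatter. Compound 2 `CC[C@@H](CCn1cncn1)c1ccc(C)cc1` in this assay gives 79.4 ug/mL. Compound 3 `Cc1ccc([C@H](CCn2cncn2)Cc2ccccc2)cc1` in this assay gives 117 ug/mL.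

Two measured steps are known. The step of a 1.1-fold lower number from compound 1 to compound 2 (0.03 log units; within the scatter) is consistent with the fact that compounds 1 and 2 differ only in the configuration as drawn. The step of a 1.5-fold higher number from compound 2 to compound 3 (0.17 log units; within the scatter), phenyl in place of methyl on a saturated chain carbon, likewise stays within the scatter.

Compound 4 `Cc1ccc([C@@H](CCn2cncn2)C2CCCCC2)cc1` is not yet measured. It differs from compound 1 by cyclohexyl in place of ethyl on a saturated chain carbon bound to an aromatic carbon and a saturated chain carbon. The step from compound 2 to compound 3 is the nearer precedent, a change of a carbon group on the chain, and it produced no movement beyond the scatter; the configuration step from compound 1 to compound 2 was flat as well. Accordingly no step beyond the scatter is expected in this assay, and compound 4 is expected to give about 90 ug/mL, a step of a 1.1-fold higher number from compound 1 to compound 4 (0.02 log units; within the scatter), with a range from 45 ug/mL to 180 ug/mL.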

Compound 4, half-maximal cytotoxic concentration: 57.9 ug/mL
For compound 4 the middle estimate is 1.6-fold (0.19 log units) above the measured one, within the range that was stated.
By their numbers in this assay, from the lowest: compounds 4, 2, 1 and 3 (each within the scatter of the next, the first and the last beyond it).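

The step of a 1.5-fold lower number from compound 1 to compound 4 (0.17 log units; within the scatter) in this assay shows that a six-membered non-aromatic ring of carbon only can stand in place of ethyl on this saturated chain carbon, bound to an aromatic carbon and a saturated chain carbon, without a move beyond the scatter. The earlier steps shown here covered configuration and phenyl in place of methyl two bonds along the chain from an aromatic carbon, so this step alone puts a non-aromatic ring on the carbon itself. No measurement shown here speaks to what lies behind this step.

On these data alone, both groups at this position consist of carbon only, so an amine or a carboxylic acid there remains open. Also open, as far as these compounds go, is whether a longer chain in place of ethyl would stay within the scatter in this assay.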